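Furan Position Swap Across Two Related Cores

The compounds below may be only part of what the source reports. "The series", "measured", "known", "first", "only" and "open" are said of these compounds alone.

Compound 1 `Cc1cc(-c2ccco2)cn2c(CSCCc3ccccc3)cnc12` and compound 2 `Cc1cc(-c2ccoc2)cn2c(CSCCc3ccccc3)cnc12` share one core, while compound 3 `Cc1cc(-c2ccco2)c2ncc(CSCCc3ccccc3)n2c1` and compound 4 `Cc1cc(-c2ccoc2)c2ncc(CSCCc3ccccc3)n2c1` share another; the difference between the two cores is not broken down here. In an ADME assay on HEL cells (Homo sapiens) for cytotoxicity, with a stated time of 3 days (on this read-out higher numbers stand for lower toxicity in this test and lower numbers for higher toxicity in this test), compound 1 gives 40 ug/mL, compound 2 gives 12 ug/mL, and compound 3 gives 41 ug/mL. The change furan-3-yl in place of furan-2-yl on an aromatic carbon produced a 3.3-fold lower number from compound 1 to compound 2 (0.52 log units; beyond the scatter). The change furan-3-yl in place of furan-2-yl on an aromatic carbon is the same kind of change, though its surroundings differ: in compound 4 the place is ortho to a fused ring and meta to a fused ring, whereas in compound 2 it is para to a fused ring. Among the compounds with values here, compound 4 is expected to show a 3.2-fold lower number from compound 3 to compound 4 (0.50 log units; beyond the scatter), because the one measured example a 3.3-fold lower number from compound 1 to compound 2 (0.52 log units; beyond the scatter) lies beyond the scatter. Compound 4 is therefore estimated at 13 ug/mL, with a range from 6 ug/mL to 28 ug/mL.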

Compound 4, half-maximal cytotoxic concentration: 64 ug/mL
Compound 4: middle estimate off by 4.9-fold (0.69 log units), on the low side; measured number above the stated range.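

On the second core, the swap of furan-2-yl for furan-3-yl gives a 1.6-fold higher number from compound 3 to compound 4 (0.19 log units; within the scatter) in this assay. The change did not carry over from one core to the other with the same size: the same change on two cores in this assay, a 3.3-fold lower number (0.52 log units; beyond the scatter) from compound 1 to compound 2 and a 1.6-fold higher number (0.19 log units; within the scatter) from compound 3 to compound 4, 5.2-fold (0.72 log units) apart, beyond the scatter of two such steps. The result for this change on one core is therefore a poor guide to its result on the other in this series, but with a single pair on each core it does not show which feature of the cores matters or how the change would behave on a further core.

Every compound shown carries a furan and the same side chain. Going by these compounds, it stays open whether a thiophene in place of the furan, or a shorter chain or an amine in that side chain, would show the same dependence on the core.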